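Carbonyl substituent variation on the shared core

This account rests on a few compounds, and the source may have more. Where it says the series, first, only, none or still open, it means among the compounds named here.

Measured compounds:
compound 1 `Cc1nc(S(C)(=O)=O)ccc1Oc1ncnc(OC2CCN(C(=O)OC(C)(C)CF)CC2)c1F`: 95%
compound 2 `Cc1nc(S(C)(=O)=O)ccc1Oc1ncnc(OC2CCN(C(=O)O[C@H](C)C(F)(F)F)CC2)c1F`: 85%
compound 3 `CCC1(OC(=O)N2CCC(Oc3ncnc(Oc4ccc(S(C)(=O)=O)nc4C)c3F)CC2)CC1`: 83%

In a functional assay on isolated protein for inhibition of Glucose-dependent insulinotropic receptor (Rattus norvegicus), read by HTRF and cAMP accumulation (a lower number here means a smaller maximal response, a higher number a larger maximal response), compound 2 gives 85%, the second highest of the three numbers, and its gaps to the other two are both within the scatter. The measured steps are all small: a number 10 percentage points lower from compound 1 to compound 2 (within the scatter), a number 2 percentage points lower from compound 2 to compound 3 (within the scatter), and only a number 12 percentage points lower from compound 1 to compound 3 (beyond the scatter) reaches beyond the scatter. Every one of these steps swaps one group for another on an oxygen next to a carbonyl group, so the maximal response barely moves when that group is varied.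

Compound 4 `Cc1nc(S(C)(=O)=O)ccc1Oc1ncnc(OC2CCN(C(=O)c3noc(C(C)(C)F)n3)CC2)c1F` differs from compound 2 as follows: a group of 9 heavy atoms (5 carbon, 2 nitrogen, 1 oxygen, 1 fluorine; one five-membered aromatic ring with 3 hetero atoms) in place of a group of 7 heavy atoms (3 carbon, 1 oxygen, 3 fluorine; no ring), on a carbonyl carbon. Here the oxygen of the ester leaves as well, so none of the measured steps covers this kind of change directly; they show only that the three compounds so far all reach a large maximal response. The expectation is therefore a step of about a number 3 percentage points lower from compound 2 to compound 4 (within the scatter), likely no change beyond the scatter, with added uncertainty. Compound 4 is estimated at 82%, with a range from 64% to 97%.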

Compound 4, largest response reached (reported as efficacy), in percent of the reference or control that the assay uses: 74%
Compound 4: middle estimate off by 8 percentage points, on the high side; low and high end bracket the measured number.
By their numbers in this assay, from the lowest: compounds 4, 3, 2 and 1 (each within the scatter of the next, the first and the last beyond it).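

In this assay, the five-membered aromatic ring with 3 hetero atoms on a carbonyl carbon gives a number 11 percentage points lower from compound 2 to compound 4 (beyond the scatter) and a number 21 percentage points lower from compound 1 to compound 4 (beyond the scatter), whereas a number 9 percentage points lower from compound 3 to compound 4 (within the scatter). This place is therefore not fully indifferent to variation: a change that also removes the oxygen can move the maximal response beyond the scatter, although compound 3 goes against this pattern, and compound 4 still reaches 74%. No measurement at hand bears on the origin of these steps.

The oxygen leaves and the ring enters in the same change, so these compounds cannot show which of the two goes with the steps. A dimethylamino group or a phenyl ring on the same carbonyl carbon would help to separate the two.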